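This account rests on a few compounds, and the source may have more. Where it says the series, first, only, none or still open, it means among the compounds named here.

Measured compounds:
Compound 1, `CCO/C(O)=C1\C(COCCN2CC(=O)NC2=O)=NC(C)=C(C(=O)OC)C1c1cccc(Cl)c1Cl` — in a functional assay (aorta) with Rattus norvegicus as the target (a lower number here means a stronger inhibitor, a higher number a weaker inhibitor), compound 1 gives 3.16 nM.
Compound 3, `CCO/C(O)=C1\C(COCCn2ccnn2)=NC(C)=C(C(=O)OC)C1c1cccc(Cl)c1Cl` — in this assay compound 3 gives 5.01 nM.
Compound 2, `CCO/C(O)=C1\C(COCCn2cc(N)n(C)c2=O)=NC(C)=C(C(=O)OC)C1c1ccccc1Cl` — in this assay compound 2 gives 25.1 nM.

Among these three, compound 2 has the highest number. Compound 3 is the nearest to it and compound 1 the furthest, and both of those gaps lie beyond the scatter. Within the data shown here, compound 2 also carries a phenyl ring with one chlorine where compounds 1 and 3 carry two; no single-change step covers that difference, so only the values themselves speak to it.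

Compound 4, `CCO/C(O)=C1\C(COCCn2cnc3ccccc32)=NC(C)=C(C(=O)OC)C1c1ccccc1Cl`, is made from compound 2 by one change: a group of 9 heavy atoms (7 carbon, 2 nitrogen; one five-membered aromatic ring with 2 hetero atoms, one six-membered aromatic ring of carbon only) in place of a group of 8 heavy atoms (4 carbon, 3 nitrogen, 1 oxygen; one five-membered aromatic ring with 2 hetero atoms), on a saturated chain carbon, two bonds along the chain from an oxygen on a saturated carbon. Among the measured compounds shown here, the only measured step at the same place is a 1.6-fold higher number from compound 1 to compound 3 (0.20 log units; within the scatter), which exchanged one small heterocycle for another on that chain carbon and stayed within the scatter. For the measured compounds named here, with that as the sole precedent, the author expects the 1H-benzimidazol-1-yl group to move the number little, so the step of a 1.0-fold lower number from compound 2 to compound 4 (0.00 log units; within the scatter) is estimated to fall within the scatter and in no firm direction. For compound 4 the estimate is 25 nM, with a range from 8 nM to 80 nM.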

Compound 4, half-maximal inhibitory concentration: 20 nM
The estimate for compound 4 lay 1.3-fold (0.10 log units) above the measured number; measured number inside the range.
By their numbers in this assay, from the lowest: compounds 1 and 3 (each within the scatter of the next); then compounds 4 and 2 (each within the scatter of the next).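

In this assay, the step of a 1.3-fold lower number from compound 2 to compound 4 (0.10 log units; within the scatter) lies within the scatter and gives a second exchange of groups on this saturated chain carbon, now in a compound with one chlorine on the phenyl ring rather than two. Here the entering 1H-benzimidazol-1-yl group adds a six-membered aromatic ring of carbon only and has 0 hydrogen-bond donors, whereas the group it replaces has 1 donor, yet the change in the number stays within the scatter, so among the listed compounds neither exchange at this place has moved it beyond the scatter. Nothing shown explains this result.

Going by these compounds, whether an amine, a carboxylic acid or a longer chain at this place would leave the number equally unchanged remains open. No pair shown differs only in the chlorines on the phenyl ring, so the effect of that difference also remains open.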